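Propyl to difluoromethyl on the aromatic oxygen: compound 4

The compounds below may be only part of what the source reports. "The series", "measured", "known", "first", "only" and "open" are said of these compounds alone.

Three members of the series have been run in an ADME assay on microsomes from liver (Mus musculus) for metabolic stability; on this read-out higher numbers stand for fast clearance and lower numbers for slow clearance. Compound 1 `CCOc1cc([C@](O)(CCN(C)C)[C@H](c2cccc(C)c2)c2cc3cc(Br)ccc3nc2OC)cc(OC)n1` gives 7.8 uL/min. Compound 2 `COc1cc([C@](O)(CCN(C)C)[C@@H](c2cc3cc(Br)ccc3nc2OC)c2cccc(OC)c2F)cc(OC(C)C)n1` gives 6 uL/min. Compound 3 `CCCOc1cc([C@](O)(CCN(C)C)[C@@H](c2cc3cc(Br)ccc3nc2OC)c2ccnc(OC)c2OC)cc(OC)n1` gives 6.5 uL/min. The three numbers lie close together: compound 3 sits with compound 2 as its nearest neighbour and compound 1 as its furthest, and both gaps fall within the usual scatter of this assay, so no one of the three can be set apart from the others on this read-out.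

Compound 4 `COc1cc([C@](O)(CCN(C)C)[C@@H](c2cc3cc(Br)ccc3nc2OC)c2ccnc(OC)c2OC)cc(OC(F)F)n1` is the next member and has not yet been measured. It keeps the whole of compound 3 apart from one exchange: difluoromethyl in place of propyl on an oxygen on an aromatic ring. Going by the values given here, no pair of measured compounds differs in a single place, so no measured step guides this exchange directly.

Given the narrow spread of the three measured numbers, the step from compound 3 to compound 4 is expected to stay within the scatter, a 1.2-fold lower number from compound 3 to compound 4 (0.07 log units; within the scatter), with a slight lean to slower clearance. Compound 4 is therefore estimated at 5.5 uL/min in this assay, with a range from 3 uL/min to 10 uL/min.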

Compound 4, intrinsic clearance in a liver preparation (reported as CLH), per the amount of preparation that the assay uses: 4.9 uL/min
For compound 4 the middle estimate is 1.1-fold (0.05 log units) above the measured one; the measured number falls inside the stated range.
By their numbers in this assay, from the lowest: compounds 4, 2, 3 and 1 (each within the scatter of the next).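

In this assay, going by these compounds alone, the exchange of propyl for difluoromethyl on an oxygen on an aromatic ring provides the first comparison between two compounds that differ in one place: a 1.3-fold lower number from compound 3 to compound 4 (0.12 log units; within the scatter). Within the data shown here, the step stays within the scatter, so this position accepts a plain carbon chain or a fluorinated group of equal heavy-atom count with no distinguishable difference on this read-out, and the single pair gives no sign that the read-out responds to this change. No supporting measurement bears on this result, so the step stands as an observation alone.

The compounds shown leave open whether a different group on this oxygen, such as trifluoromethyl, a longer chain such as butyl, or a chain ending in an amine, would produce a step beyond the scatter. Among these compounds, it also remains open whether the exchange of propyl for difluoromethyl would stay within the scatter on the rest of compound 1 or compound 2, since the only reading so far comes from the single background shared by compound 3 and compound 4.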